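Bromo to 2-(pyridin-3-yl)ethynyl: working notes on compound 4

The compounds below may be only part of what the source reports. "The series", "measured", "known", "first", "only" and "open" are said of these compounds alone.

In an ADME assay on MT4 cells (Homo sapiens) for cytotoxicity, read by XTT assay, with a stated time of 5 days (on this read-out higher numbers stand for lower toxicity in this test and lower numbers for higher toxicity in this test), compound 1 `CNC(=O)[C@@H](NC(=O)[C@@](O)(CCCN(Cc1ccc(Br)cc1)NC(=O)[C@@H](NC(=O)OC)C(C)(C)C)Cc1ccccc1)C(C)(C)C` gives > 10000 nM, which is a limit of the assay. Compound 2 `CNC(=O)[C@@H](NC(=O)[C@@](O)(CCCN(Cc1ccc(Br)cc1)NC(=O)[C@@H](NC(=O)OC)C(C)(C)C)Cc1ccccc1)C(C)C` gives > 10000 nM, also a limit. Compound 3 `COC(=O)N[C@H](C(=O)NN(CCC[C@@](O)(Cc1ccccc1)C(=O)N[C@H](CO)C(C)(C)C)Cc1ccc(Br)cc1)C(C)(C)C` gives > 10000 nM, again a limit. The series therefore sits at the limit of > 10000 nM in this assay, at which 3 of the 3 values shown sit, and no number places compound 1 within it.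

In compound 4 `CNC(=O)[C@@H](NC(=O)[C@@](O)(CCCN(Cc1ccc(C#Cc2cccnc2)cc1)NC(=O)[C@@H](NC(=O)OC)C(C)(C)C)Cc1ccccc1)C(C)(C)C`, 2-(pyridin-3-yl)ethynyl takes the place of bromo on an aromatic carbon: 2-(pyridin-3-yl)ethynyl in place of bromo on an aromatic carbon.

Three measured steps are available: a step that the two limits leave unreadable from compound 1 to compound 2, a step that the two limits leave unreadable from compound 1 to compound 3 and a step that the two limits leave unreadable from compound 2 to compound 3. All three change other parts of the molecule, and none gives a readable size, so none sizes this replacement. The expectation rests on compound 1 alone, whose value of > 10000 nM is a limit. No step beyond the usual scatter is expected in either direction, and a further limit is the likeliest report. The expected change is a step that the limit leaves unreadable from compound 1 to compound 4. For compound 4 the estimate is 15000 nM, with an expected range from 6000 nM to 50000 nM.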

Compound 4, half-maximal cytotoxic concentration: > 50000 nM
Compound 4 ended at the assay's limit; the forecaster's own chance of this, stated with the estimate: 70%; at least 3.3-fold (0.52 log units) between middle value and limit.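

In this assay compound 4 gives > 50000 nM, which is a limit. Compound 1 gives > 10000 nM, also a limit, and no size can be read for the step to compound 4. The compounds shown leave open what half-maximal cytotoxic concentration any of them actually has.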